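Swapping a Methoxyphenyl for a Fluorophenyl on the Core

The source may hold more compounds than are shown below. What is called first, only, known or untested is meant among the compounds shown, and "the series" means these compounds.

Among the compounds with values here, the two compounds measured so far share one core and differ only in the aryl group attached to it. Compound 1 `CCC1=C(O)c2c(oc(-c3ccc(CC(C)C)cc3)cc2=O)C(CC)(CC)C1=O` carries a 4-isobutylphenyl and in a functional assay on KBVIN cells (Homo sapiens) for antiproliferative activity, read by sulforhodamine B assay, with a stated time of 3 days (a lower number here means that less compound is needed, a higher number that more compound is needed for the effect), compound 1 gives 17.4 uM. Compound 2 `CCC1=C(O)c2c(oc(-c3ccc(OC)cc3)cc2=O)C(CC)(CC)C1=O` carries a 4-methoxyphenyl instead, and in this assay compound 2 gives 0.68 uM, the lowest of the two numbers; the step of a 26-fold lower number from compound 1 to compound 2 (1.41 log units; beyond the scatter) is large and beyond the scatter.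

Compound 3 `CCC1=C(O)c2c(oc(-c3cccc(F)c3)cc2=O)C(CC)(CC)C1=O` is the unmeasured member: 3-fluorophenyl in place of 4-methoxyphenyl on an aromatic carbon. Within the data shown here, no measured step replaces a methoxyphenyl with a fluorophenyl, so the one step that bears on it is a 26-fold lower number from compound 1 to compound 2 (1.41 log units; beyond the scatter), which shows only that the substituent on this aryl ring can move the number a long way. Because compound 2 owes its low value of 0.68 uM to the 4-methoxyphenyl, losing that group is expected to cost some potency, though not the full gap back to compound 1. The estimated step is a 4.4-fold higher number from compound 2 to compound 3 (0.64 log units; beyond the scatter), upward. Compound 3 is therefore expected at about 3 uM in this assay, within 0.7 uM to 14 uM.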

Compound 3, concentration for half-maximal effect: 3.09 uM
For compound 3 the middle estimate is 1.0-fold (0.01 log units) below the measured one; the range from low to high includes it.
By their numbers in this assay, from the lowest: compound 2; then compound 3; then compound 1.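

The step of a 4.5-fold higher number from compound 2 to compound 3 (0.66 log units; beyond the scatter) in this assay shows that the 4-methoxyphenyl on this aromatic carbon, next to the ring oxygen, can be given up at a modest cost, and that the oxygen of its methoxy group is not needed to stay well short of the number for the 4-isobutylphenyl. With compound 3 at 3.09 uM, the order runs compound 2, compound 3, compound 1, so the aryl groups now span a graded series rather than a single large gap. No measurement here explains why the 3-fluorophenyl falls where it does.

This single change swaps the substituent and also moves it around the aryl ring, so the compounds shown cannot separate the effect of fluorine replacing methoxy from the effect of where the substituent sits. They also leave open how an unsubstituted phenyl, or an aryl ring carrying an amine or a carboxylic acid, would read in this assay.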